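Glycine transporter series: benzyloxy in place of isopropoxy

This account rests on a few compounds, and the source may have more. Where it says the series, first, only, none or still open, it means among the compounds named here.

compound 1 `COc1cccc2c1CN(C(=O)c1cc(S(C)(=O)=O)ccc1O[C@@H](C)C(F)(F)F)C2`: 1940 nM
compound 2 `CC(C)Oc1ccc(S(C)(=O)=O)cc1C(=O)N1Cc2cc(C(F)(F)F)cnc2C1`: 70 nM
compound 3 `CS(=O)(=O)c1ccc(OCCC(F)(F)F)c(C(=O)N2Cc3ccc(C4CCOCC4)cc3C2)c1`: 137 nM

In an assay on CHO cells for inhibition of sodium- and chloride-dependent glycine transporter 1 (Homo sapiens), read by scintillation counting (a higher number here means that more compound is needed for the effect, a lower number that less compound is needed), compound 2 shows the lowest number of the three, though compound 3 sits within the scatter of it; only compound 1 lies beyond the scatter, far above compound 2. Going by the values given here, no pair of measured compounds differs in a single place, so no measured step informs the next change.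

Compound 4 `CS(=O)(=O)c1ccc(OCc2ccccc2)c(C(=O)N2Cc3cc(C(F)(F)F)cnc3C2)c1` differs from compound 2 by benzyl in place of isopropyl on an oxygen on an aromatic ring. Lacking any measured step at this oxygen, the expectation for the move from compound 2 to compound 4 is a change of a 1.6-fold higher number from compound 2 to compound 4 (0.20 log units; within the scatter), which is held near the scatter and leans toward a somewhat higher number. For compound 4 in this assay the estimate is 110 nM, with a range from 35 nM to 400 nM.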

Compound 4, half-maximal effective concentration in the sodium- and chloride-dependent glycine transporter 1 assay: 805 nM
For compound 4 the middle estimate is 7.3-fold (0.86 log units) below the measured one; measured number outside the range, above it.
By their numbers in the sodium- and chloride-dependent glycine transporter 1 assay, from the lowest: compounds 2 and 3 (each within the scatter of the next); then compound 4; then compound 1.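

Going by these compounds alone, at this oxygen on an aromatic ring, the change from isopropoxy to benzyloxy is the first single-place step, and in the sodium- and chloride-dependent glycine transporter 1 assay it is large, with compound 2 at 70 nM and compound 4 at 805 nM: a 12-fold higher number from compound 2 to compound 4 (1.06 log units; beyond the scatter). In a physicochemical assay for solubility (a lower number here means a less soluble compound, a higher number a more soluble compound), the same change stays within the scatter, with compound 2 at 114 ug/mL and compound 4 at 72 ug/mL: a 1.6-fold lower number from compound 2 to compound 4 (0.20 log units; within the scatter). No measurement at hand accounts for the size of the step in the first of these readings.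

Open, as far as these compounds go, is how an ethyl or a cyclohexylmethyl group on this oxygen would read in the sodium- and chloride-dependent glycine transporter 1 assay. Those two groups would show whether the aromatic ring of benzyl or its added carbons go with the step.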